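Polyol to dimethyl-dioxolane swap on the shared core

The compounds below may be only part of what the source reports. "The series", "measured", "known", "first", "only" and "open" are said of these compounds alone.

The three measured compounds share one core and differ only in the group on the aromatic nitrogen: compound 1 `O=C1c2c[n+]([O-])c3ccccc3c2C(=O)c2c1c1ccccc1n2Cc1cn(C[C@@H](O)CO)nn1` carries 2,3-dihydroxypropyl, compound 2 `CC1(C)O[C@@H](CO)[C@H](Cn2cc(Cn3c4c(c5ccccc53)C(=O)c3c[n+]([O-])c5ccccc5c3C4=O)nn2)O1` carries (5-(hydroxymethyl)-2,2-dimethyl-1,3-dioxolan-4-yl)methyl, and compound 3 `O=C1c2c[n+]([O-])c3ccccc3c2C(=O)c2c1c1ccccc1n2Cc1cn([C@H]2O[C@H](CO)[C@@H](O)[C@H]2O)nn1` carries 3,4-dihydroxy-5-(hydroxymethyl)oxolan-2-yl. In a toxicity assay on L02 cells (Homo sapiens) for cytotoxicity, read by MTT assay, with a stated time of 72 h (on this read-out higher numbers stand for weaker inhibition and lower numbers for stronger inhibition), compound 1 gives 490 nM, compound 2 gives 500 nM and compound 3 gives 950 nM. Compound 3 shows the highest of the three numbers, yet a 1.9-fold higher number from compound 1 to compound 3 (0.29 log units; within the scatter) and a 1.9-fold higher number from compound 2 to compound 3 (0.28 log units; within the scatter) are both within the scatter, as is a 1.0-fold higher number from compound 1 to compound 2 (0.01 log units; within the scatter) — nothing separates the three.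

Compound 4 `CC1(C)OC[C@H](Cn2cc(Cn3c4c(c5ccccc53)C(=O)c3c[n+]([O-])c5ccccc5c3C4=O)nn2)O1` is compound 3 with (2,2-dimethyl-1,3-dioxolan-4-yl)methyl in place of 3,4-dihydroxy-5-(hydroxymethyl)oxolan-2-yl on an aromatic nitrogen. The closest comparison is the step from compound 2 to compound 3, which moves between a dimethyl-dioxolane and the oxolane and stayed within the scatter; the step from compound 1 to compound 2, introducing the dimethyl-dioxolane, likewise showed nothing beyond the scatter. No step beyond the scatter is therefore expected in this assay. Compound 4 is estimated at 650 nM with a range of 280 nM to 1500 nM. The expected step of a 1.5-fold lower number from compound 3 to compound 4 (0.16 log units; within the scatter) is thus taken to lie within the scatter.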

Compound 4, half-maximal inhibitory concentration: 470 nM
Compound 4: the middle estimate sits 1.4-fold (0.14 log units) above what was measured; low and high end bracket the measured number.
By their numbers in this assay, from the lowest: compounds 4, 1, 2 and 3 (each within the scatter of the next, the first and the last beyond it).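

Among the compounds shown here, at the aromatic nitrogen, (2,2-dimethyl-1,3-dioxolan-4-yl)methyl in place of 3,4-dihydroxy-5-(hydroxymethyl)oxolan-2-yl gives the first step in this assay printed beyond the scatter, though only a modest one (a 2.0-fold lower number from compound 3 to compound 4 (0.31 log units; beyond the scatter)). Hydrogen in place of hydroxymethyl on the saturated ring carbon stays within the scatter (a 1.1-fold lower number from compound 2 to compound 4 (0.03 log units; within the scatter)), as does 2,2-dimethyl-1,3-dioxolan-4-yl in place of 1,2-dihydroxyethyl (a 1.0-fold lower number from compound 1 to compound 4 (0.02 log units; within the scatter)), so a group with 0 hydrogen-bond donors is accommodated here without a separable change from the open-chain diol. Nothing on hand accounts for the step from the oxolane.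

The exchange alters the ring, the hydroxyl groups and the link to the nitrogen together, and the compounds shown cannot assign the step to any one of these. On these data alone, how an amine or a carboxylic acid on a longer chain at this aromatic nitrogen would read remains open.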